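Hydroxy for acetamido on a thiocarbamate core

The source may hold more compounds than are shown below. What is called first, only, known or untested is meant among the compounds shown, and "the series" means these compounds.

Compound 2 `CC(=O)Nc1ccc(OC(=S)Nc2ccc(Nc3ccc(C(F)(F)F)cc3)cc2)cc1` gives 5.32 in a physicochemical assay for lipophilicity (a higher number here means a more lipophilic compound, a lower number a more polar compound), which is the second highest of the three numbers measured. Compound 1 `CC(=O)Nc1ccc(OC(=S)Nc2ccc(Nc3ccc([N+](=O)[O-])cc3)cc2)cc1` gives 4.32 in this assay, and compound 3 `Oc1ccc(OC(=S)Nc2ccc(Oc3ccc(C(F)(F)F)cc3)cc2)cc1` gives 6.11. Among the compounds with values here, the one measured step that differs in a single place, a number 1.00 log units higher from compound 1 to compound 2 (beyond the scatter), concerns the trifluoromethyl and the nitro, not the group that changes here.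

Compound 4 `Oc1ccc(OC(=S)Nc2ccc(Nc3ccc(C(F)(F)F)cc3)cc2)cc1` is not yet measured. It differs from compound 2 by hydroxy in place of acetamido on an aromatic carbon. Within the data shown here, no measured pair isolates this change: compound 3 carries the hydroxy but differs from compound 2 in a second place as well, so the distance between compound 2 at 5.32 and compound 3 at 6.11 is no clean step for it, only an indication of where a hydroxy-bearing analogue of this core can lie. Among the measured compounds shown here, exchanging the acetamido group, with its four heavy atoms, for the single-atom hydroxy is expected to raise the number, though the data give no measured step of this kind.

The step from compound 2 to compound 4 is therefore estimated at a number 0.33 log units higher from compound 2 to compound 4 (beyond the scatter). Compound 4 is expected to give about 5.65 in this assay, within a range from 5.15 to 6.15.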

Compound 4, partition coefficient: 6.04
Beside the measured number, compound 4's estimate is 0.39 log units below it, and the stated range covers the measured number.
By their numbers in this assay, from the lowest: compound 1; then compound 2; then compounds 4 and 3 (each within the scatter of the next).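

With the rest of compound 2 left unchanged, the exchange of 4-acetamidophenyl to 4-hydroxyphenyl gives in this assay a step of a number 0.72 log units higher from compound 2 to compound 4 (beyond the scatter) and so shows that this change, on an aromatic carbon para to a large group, moves the number on its own, with no second difference involved. The step is modest, the same printed size as a number 1.00 log units higher from compound 1 to compound 2 (beyond the scatter) at the trifluoromethyl and nitro place, so both places of the series now have one clean measured exchange. Compound 4 at 6.04 and compound 3 at 6.11 lie within the scatter of each other, so the one place in which they differ shows no readable change in this assay, and no measurement shown here explains the step from acetamido to hydroxy.

The compounds shown leave open what a methoxy group, an amine or a carboxylic acid would give at this same aromatic carbon, and so whether the step follows the number of heavy atoms in the group or something else. They also leave open whether hydroxy in place of acetamido gives a step of similar size when nitro replaces the trifluoromethyl.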